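The compounds below may be only part of what the source reports. "The series", "measured", "known", "first", "only" and "open" are said of these compounds alone.

Series notes: in a functional assay on PC-3 cells (Homo sapiens) for antiproliferative activity, read by MTT assay, with a stated time of 72 h (on this read-out lower numbers stand for stronger inhibition and higher numbers for weaker inhibition), compound 1 `O=C(N/N=C/c1ccccc1)Nc1ccc(Oc2ccnc3[nH]ccc23)c(F)c1` gives 7940 nM and compound 2 `O=C(N/N=C/c1ccccc1)Nc1ccc(Oc2ccnc3[nH]ccc23)cc1` gives 10200 nM as the only two numbers so far. Compound 2 therefore has a single neighbour, and the two sit within the scatter of each other. Within the data shown here, the one measured step, a 1.3-fold higher number from compound 1 to compound 2 (0.11 log units; within the scatter), is hydrogen in place of fluoro on an aromatic carbon and does not touch the phenyl group.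

Compound 3 `O=C(N/N=C/c1ccc(O)cc1)Nc1ccc(Oc2ccnc3[nH]ccc23)cc1` differs from compound 2 by hydroxy in place of hydrogen on an aromatic carbon, phenyl to 4-hydroxyphenyl. Among the measured compounds shown here, no measured step covers this change, so the data give no firm direction, and the range stays wide. No shift beyond the scatter is expected in this assay on this evidence. The expected step is a 1.3-fold lower number from compound 2 to compound 3 (0.11 log units; within the scatter). Compound 3 is estimated at 8000 nM, with an expected range from 2500 nM to 25000 nM.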

Compound 3, half-maximal inhibitory concentration: 4920 nM
Compound 3: middle estimate off by 1.6-fold (0.21 log units), on the high side; the measured number falls inside the stated range.
By their numbers in this assay, from the lowest: compounds 3, 1 and 2 (each within the scatter of the next, the first and the last beyond it).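

In this assay, hydroxy in place of hydrogen on an aromatic carbon, para to a large group, gives a 2.1-fold lower number from compound 2 to compound 3 (0.32 log units; beyond the scatter), a modest change but the first in the series beyond the scatter. Among these compounds, the only earlier step, a 1.3-fold higher number from compound 1 to compound 2 (0.11 log units; within the scatter), lay within the scatter and left the phenyl group untouched, so this pair is the first sign that a substituent on that ring can shift the antiproliferative read-out, although it rests on a single pair. No measurement here accounts for the shift.

From the compounds shown here alone, it remains open whether the gain is specific to hydroxy or would also appear with a methoxy group, an amine or a carboxylic acid on the same carbon. Going by these compounds, it is also open whether the same change would carry over to compound 1, which has the fluoro group.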